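Stripping the Aryl Tail from a Cyanoguanidine Antagonist

The source may hold more compounds than are shown below. What is called first, only, known or untested is meant among the compounds shown, and "the series" means these compounds.

Compound 3 `CC(CCN/C(=N\C#N)NCCCCc1c[nH]cn1)c1ccccc1` shares its core with compound 1 `N#C/N=C(/NCCCCc1c[nH]cn1)NCCCc1ccccc1` and compound 2 `N#C/N=C(/NCCCCc1c[nH]cn1)NCCCc1cccnc1`. In an in vitro functional assay on Sf9 cells for antagonist activity at histamine H2 receptor (Homo sapiens) (a lower number here means a less potent compound, a higher number a more potent compound, by a factor of ten per unit of this negative logarithm), compound 1 gives 5.25. In this assay compound 2 gives 5.92. For compound 3 this assay reports only a limit, < 5, so compound 3 sits at the floor of what the assay can resolve (the limit of < 5 in this assay, at which 1 of the 3 values shown sits). The two steps that reach it, a number at least 0.25 log units lower from compound 1 to compound 3 (that floor lies within the scatter) and a number at least 0.92 log units lower from compound 2 to compound 3 (beyond the scatter), both run downward into that floor.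

Compound 4 `CCN/C(=N\C#N)NCCCCc1c[nH]cn1` differs from compound 3 by hydrogen in place of 1-phenylethyl on a saturated chain carbon, two bonds along the chain from an amine nitrogen. Among the measured compounds shown here, no measured step removes the whole aryl tail, so the measured steps only frame the question: adding a methyl, in a number at least 0.25 log units lower from compound 1 to compound 3 (that floor lies within the scatter), pushed the value down, while swapping phenyl for pyridin-3-yl, in a number 0.67 log units higher from compound 1 to compound 2 (beyond the scatter), lifted it. Without the tail, compound 4 is expected to stay close to the floor, an estimated 4.9 in this assay, within 4.3 to 5.5. The expected step is a step that the limit leaves unreadable from compound 3 to compound 4.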

Compound 4, negative logarithm of the antagonist equilibrium constant: < 5
Compound 4: only a limit was reported (the forecaster's own chance of this, stated with the estimate: 55%); the middle value is on the limit's open side.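

Replacing (pyridin-3-yl)methyl with hydrogen at this position gives a number at least 0.92 log units lower from compound 2 to compound 4 (beyond the scatter) in this assay, so the tail of compound 2 clearly contributes to its value. Replacing benzyl with hydrogen gives a number at least 0.25 log units lower from compound 1 to compound 4 (that floor lies within the scatter), and so this result cannot show that the benzyl of compound 1 contributes anything beyond the scatter. The step from compound 3 to compound 4 cannot be read, and the two compounds share the same limit: the limit of < 5 in this assay, at which 2 of the 4 values shown sit.

On these data alone, how far compound 3 and compound 4 lie beneath that limit remains unknown, so it is open whether the tail of compound 3 contributes anything at all. As far as these compounds go, it is also open whether a longer chain carrying the pyridin-3-yl ring, or an amine on that ring, would raise the value beyond that of compound 2.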